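Swapping a cyclohexyl for a pyridinylmethyl on the ether oxygen

The compounds below may be only part of what the source reports. "The series", "measured", "known", "first", "only" and "open" are said of these compounds alone.

Of the compounds shown here, two sharing one core have been measured so far. Compound 1 `CC(C(=O)NCc1ccc(C(F)(F)Cl)nc1N1CCCCC1)c1ccc(NS(C)(=O)=O)c(F)c1` gives 1.3 nM in an assay on CHO cells for antagonist activity at transient receptor potential cation channel subfamily V member 1 (Homo sapiens), read by FLIPR; a higher number here means a weaker inhibitor, a lower number a stronger inhibitor. Compound 2 `CC(C(=O)NCc1ccc(C(F)(F)Cl)nc1OC1CCCCC1)c1ccc(NS(C)(=O)=O)c(F)c1` gives 0.9 nM in this assay. Going by the values given here, the only step between them, a 1.4-fold lower number from compound 1 to compound 2 (0.16 log units; within the scatter), is within the scatter, so compound 2 has the lowest of the two numbers without standing apart from compound 1. Compound 3 `CC(C(=O)NCc1ccc(C(F)(F)Cl)nc1OCc1cccnc1)c1ccc(NS(C)(=O)=O)c(F)c1` differs from compound 2 by (pyridin-3-yl)methyl in place of cyclohexyl on an oxygen on an aromatic ring. Among the compounds with values here, no measured step touches this position in the same way: the single step that has been measured alters the atom attached to the aromatic carbon rather than the group on the oxygen, and it was small. The expectation for compound 3 is therefore a modest weakening, a 2.8-fold higher number from compound 2 to compound 3 (0.44 log units; beyond the scatter), with wide uncertainty. Compound 3 is estimated at 2.5 nM, within a range from 0.6 nM to 10 nM.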

Compound 3, inhibition constant: 14.6 nM
The estimate for compound 3 lay 5.8-fold (0.77 log units) below the measured number; the measured number lies above the stated range.
By their numbers in this assay, from the lowest: compounds 2 and 1 (each within the scatter of the next); then compound 3.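

The group on this oxygen matters far more than the earlier pair suggested: in this assay, (pyridin-3-yl)methyl in place of cyclohexyl gives a large loss (a 16-fold higher number from compound 2 to compound 3 (1.21 log units; beyond the scatter)), whereas the swap from piperidin-1-yl to cyclohexyloxy stayed within the scatter. The loss also appears against the piperidine compound (an 11-fold higher number from compound 1 to compound 3 (1.05 log units; beyond the scatter)), so this position does not accept every six-membered ring group equally. Nothing shown here gives a reason for this loss.

The change replaces a ring of carbon only with an aromatic ring holding a nitrogen, and it also adds a methyl link to the oxygen, so these two differences cannot be told apart. Benzyl or cyclohexylmethyl on the same oxygen would show which of them goes with the weaker number.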